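The source may report more compounds than this note shows. Statements on the series, on what has been measured and on what is new or still open speak of the compounds shown alone.

In an assay on isolated protein for displacement of a labelled ligand from Adrenergic receptor alpha-1 (Rattus norvegicus) (a lower number here means a stronger inhibitor, a higher number a weaker inhibitor), the two measured compounds read as follows:

compound 1, `CCNC(=O)C1CCN(c2nc(N)c3cc(OC)c(OC)cc3n2)CC1`: 1.64 nM
compound 2, `CCCCNC(=O)CC1CCN(c2nc(N)c3cc(OC)c(OC)cc3n2)CC1`: 1.4 nM

Both share one core and differ only in the side chain carried on the saturated ring carbon. Compound 2 stands beside compound 1 on these two numbers, the step between them being a 1.2-fold lower number from compound 1 to compound 2 (0.07 log units; within the scatter). Compound 3 `CCCCNC(=O)CCC1CCN(c2nc(N)c3cc(OC)c(OC)cc3n2)CC1` is the next member of the set: (butylcarbamoyl)methyl in place of butylcarbamoyl on a saturated chain carbon bound to a saturated ring carbon. Within the data shown here, the one measured step that bears on this change is the step from compound 1 to compound 2, in which the chain was also lengthened while the alkyl on the amide nitrogen changed at the same time, and that step stayed within the scatter, a 1.2-fold lower number from compound 1 to compound 2 (0.07 log units; within the scatter). Whether a further lengthening of the same chain behaves alike cannot be read from two compounds alone, but nothing in them points to a step beyond the scatter in this assay in either direction. Compound 3 is therefore expected to give about 1.6 nM, within a range of 0.6 nM to 4.5 nM, which corresponds to an expected step of a 1.1-fold higher number from compound 2 to compound 3 (0.06 log units; within the scatter).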

Compound 3, inhibition constant: 0.47 nM
The estimate for compound 3 lay 3.4-fold (0.53 log units) above the measured number; the whole stated range lies above it.
By their numbers in this assay, from the lowest: compound 3; then compounds 2 and 1 (each within the scatter of the next).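

In this assay, the side chain on the saturated ring carbon proves able to shift the number: the change from (butylcarbamoyl)methyl to 2-(butylcarbamoyl)ethyl gives a 3.0-fold lower number from compound 2 to compound 3 (0.47 log units; beyond the scatter), whereas the earlier change gave only a 1.2-fold lower number from compound 1 to compound 2 (0.07 log units; within the scatter). Set against the short side chain of compound 1, 2-(butylcarbamoyl)ethyl in place of ethylcarbamoyl gives a 3.5-fold lower number from compound 1 to compound 3 (0.54 log units; beyond the scatter), so compound 3 is the strongest of the three in this assay, and the response to chain length is not even across these compounds. The data offer nothing that accounts for this result.

Still open, going by these compounds, is whether the trend continues or reverses with a longer chain such as 3-(butylcarbamoyl)propyl, and whether the butyl group on the amide nitrogen is needed for the result, which 2-(ethylcarbamoyl)ethyl on the same ring carbon would test. On these data alone, it is equally open whether the amide itself matters, as a carboxylic acid or a simple amine at the end of the same chain would show.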